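Swapping Fluoro for Methoxy on a Toll-like Receptor 9 Antagonist

The source may report more compounds than this note shows. Statements on the series, on what has been measured and on what is new or still open speak of the compounds shown alone.

Compound 1 `CCN1CCN(CCCn2cnc3c(N4CCN(C5CCCC5)CC4)nc(NCc4ccc(F)cc4)nc32)CC1` was tested in an assay on HEK293 cells for antagonist activity at Toll-like receptor 9 (Homo sapiens), read by spectrophotometry (a higher number here means a weaker inhibitor, a lower number a stronger inhibitor), where compound 1 gives 250 nM. Of the two plain numbers recorded, this is the higher one: compound 2 `CCN1CCN(c2nc(NCc3ccc(CN(C)C)cc3)nc3c2ncn3CCCN2CCCC2)CC1` gives 90 nM in this assay, a lower number beyond the usual scatter. Compound 3 `CCN1CCN(CCCn2cnc3c(N4CCN(C(=O)C5CCCC5)CC4)nc(NCc4ccc(F)cc4)nc32)CC1` gives only > 30000 nM, which is a limit of the assay rather than a number. Compound 3 thus sits at the limit of > 30000 nM in this assay, at which 1 of the 3 values shown sits. For the measured compounds named here, the step of an at least 120-fold higher number from compound 1 to compound 3 (2.07 log units; beyond the scatter) is the only measured change from compound 1, and it concerns an amine nitrogen in a ring, not the benzyl group. Compound 4 `CCN1CCN(CCCn2cnc3c(N4CCN(C5CCCC5)CC4)nc(NCc4ccc(OC)cc4)nc32)CC1` differs from compound 1 by methoxy in place of fluoro on an aromatic carbon. Going by the values given here, no measured step touches this position, so no shift beyond the scatter is expected. The expected step is no change at the digits printed from compound 1 to compound 4 (within the scatter). Compound 4 is therefore estimated at about 250 nM, between 80 nM and 800 nM.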

Compound 4, half-maximal inhibitory concentration: 120 nM
Beside the measured number, compound 4's estimate is 2.1-fold (0.32 log units) above it; measured number inside the range.
By their numbers in this assay, from the lowest: compounds 2 and 4 (each within the scatter of the next); then compound 1. At a limit, above all of these: compound 3.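

On the six-membered aromatic ring, the carbon that carries fluoro in compound 1 turns out to respond to change: in this assay methoxy in place of fluoro gives a 2.1-fold lower number from compound 1 to compound 4 (0.32 log units; beyond the scatter) and makes compound 4 the stronger inhibitor of the pair. For the compounds shown here, the earlier step concerned an amine nitrogen in a ring, so this is the first sign that the benzyl end also matters, and that two heavy atoms fit where one stood. Nothing measured here explains the shift.

From the compounds shown here alone, whether a hydroxyl, a chlorine atom or an amine on this carbon would do as well remains open. So does whether a longer chain, such as ethoxy, would carry the shift further.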